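Swapping a Hydroxyphenyl for a Trimethoxyphenyl

The source may hold more compounds than are shown below. What is called first, only, known or untested is meant among the compounds shown, and "the series" means these compounds.

Compound 1 `CCN(CC)CCCn1c(=O)/c(=C/c2ccccc2O)s/c1=C1/C(=O)Nc2ccc(C)cc21` was tested in a functional assay on K562/Adr cells (Homo sapiens) for cytotoxicity, read by sulforhodamine B assay, with a stated time of 48 h (a lower number here means a stronger inhibitor, a higher number a weaker inhibitor), where compound 1 gives 30600 nM. Going by the values given here, that is the highest number among the compounds measured so far. Compound 3 `CCN(CC)CCCn1c(=O)/c(=C/c2ccc(F)c(F)c2)s/c1=C1/C(=O)Nc2ccc(F)cc21` comes nearest, giving 6480 nM in this assay, and compound 2 `CN(C)CCn1c(=O)/c(=C/c2ccc(O)cc2)s/c1=C1/C(=O)Nc2ccc(F)cc21` lies furthest away, giving 6140 nM; both gaps lie beyond the usual scatter. Among the compounds with values here, no pair of these measured compounds differs in only one place, so no single step can be read off directly. Compound 4 `CCN(CC)CCCn1c(=O)/c(=C/c2cc(OC)c(OC)c(OC)c2)s/c1=C1/C(=O)Nc2ccc(C)cc21` has not been measured yet. It differs from compound 1 by 3,4,5-trimethoxyphenyl in place of 2-hydroxyphenyl on a double-bonded chain carbon bound to an aromatic carbon. Within the data shown here, with no matching step available, a modest lowering of the number is expected, a 2.6-fold lower number from compound 1 to compound 4 (0.41 log units; beyond the scatter). Compound 4 is therefore estimated to give about 12000 nM in this assay, within a range from 4000 nM to 35000 nM.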

Compound 4, half-maximal inhibitory concentration: 2020 nM
Compound 4: middle estimate off by 5.9-fold (0.77 log units), on the high side; measured number outside the range, below it.
By their numbers in this assay, from the lowest: compound 4; then compounds 2 and 3 (each within the scatter of the next); then compound 1.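

At this position, on a double-bonded chain carbon bound to an aromatic carbon, the ring substituents can shift the result strongly: 3,4,5-trimethoxyphenyl in place of 2-hydroxyphenyl gives a 15-fold lower number from compound 1 to compound 4 (1.18 log units; beyond the scatter) in this assay, with the rest of the molecule unchanged. Going by these compounds alone, this is the first change in a single place that can be read here, and nothing measured explains its size. The swap removes the hydroxyl and adds the methoxy groups together, so their separate contributions stay unresolved. A plain phenyl or a ring bearing a single methoxy group would help separate them.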